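Series notes: 4-cyanophenyl in place of cyclohexyl on the ring nitrogen

A few compounds are considered here, and "the series" means these few. Any claim that something is new, unique, unknown or untested is made for them only; others in the source may bear on it.

Three compounds of the shared core have numbers in a functional assay on MGC-803 cells (Homo sapiens) for antiproliferative activity, read by CCK-8 assay, with a stated time of 72 h, tested at 8 uM; on this read-out higher numbers stand for a stronger effect at the one concentration tested and lower numbers for a weaker effect. Compound 1 `Nc1ccccc1NC(=O)c1ccc(CSC(=S)N2CCN(C3CCCCC3)CC2)cc1` gives 75.3% and stands second highest of the three. Compound 3 `Nc1ccccc1NC(=O)c1ccc(CSC(=S)N2CCCC2)cc1` gives 83.4%, a number that sits higher than that of compound 1 by an amount within the scatter, so the two cannot be ordered. Compound 2 `Nc1ccccc1NC(=O)c1ccc(CSC(=S)N2CCc3cc([N+](=O)[O-])ccc32)cc1` gives 33.2%, a number clearly below that of compound 1 and beyond the scatter.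

Compound 4 `N#Cc1ccc(N2CCN(C(=S)SCc3ccc(C(=O)Nc4ccccc4N)cc3)CC2)cc1` is the next member and has not yet been measured. It differs from compound 1 in one place: 4-cyanophenyl in place of cyclohexyl on an amine nitrogen in a ring. Within the data shown here, no pair of measured compounds shows this change, so the expectation rests only on the spread of the three numbers and on the fact that the new group sits on the same ring nitrogen that carries cyclohexyl in compound 1. A moderate lowering is expected, a number 15.3 percentage points lower from compound 1 to compound 4 (beyond the scatter), though the uncertainty is wide. Compound 4 is expected to give about 60%, with a range from 30% to 85%.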

Compound 4, a percentage reported as inhibition, at one concentration (the size of the read-out at that concentration, not a potency): 37.6%
For compound 4 the middle estimate is 22.4 percentage points above the measured one; the measured number falls inside the stated range.
By their numbers in this assay, from the lowest: compounds 2 and 4 (each within the scatter of the next); then compounds 1 and 3 (each within the scatter of the next).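

Replacing cyclohexyl with 4-cyanophenyl gives a number 37.7 percentage points lower from compound 1 to compound 4 (beyond the scatter) in this assay and shows that the group on this amine nitrogen in a ring has a large bearing on the read-out. The change swaps a non-aromatic carbon ring for an aromatic one and also adds a nitrile, so this single step cannot separate the two features. No measurement offered here accounts for this step.

From the compounds shown here alone, whether plain phenyl would stay close to compound 1 or fall as far as compound 4 remains open, as does the result of moving the nitrile to another ring carbon. Methyl or benzyl on the same nitrogen would show how far the read-out depends on the size and kind of this group.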